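The compounds below may be only part of what the source reports. "The series", "measured", "known", "first", "only" and "open" are said of these compounds alone.

Measured so far in a functional assay on HeLa cells (Homo sapiens) for inhibition, read by MTT assay; a lower number here means a stronger inhibitor, a higher number a weaker inhibitor:
Compound 1 `O=C1/C(=C\c2ccccc2)N=C(c2ccccc2)N1c1ccc2oc(-c3ccccc3)cc(=O)c2c1` gives 20.1 ug/mL.
Compound 2 `COc1ccc(/C=C2/N=C(c3ccccc3)N(c3ccc4oc(-c5ccccc5)cc(=O)c4c3)C2=O)cc1OC` gives 9.87 ug/mL.

Of these two numbers, compound 2 holds the lower one. Within the data shown here, the only measured step that bears on the change in question is the exchange of the aryl group on the double-bonded chain carbon: a 2.0-fold lower number from compound 1 to compound 2 (0.31 log units; beyond the scatter). That step was modest, though it went beyond the scatter.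

Compound 3 `O=C1/C(=C\c2ccc(O)cc2)N=C(c2ccccc2)N1c1ccc2oc(-c3ccccc3)cc(=O)c2c1` has not yet been measured. It differs from compound 2 in one place: 4-hydroxyphenyl in place of 3,4-dimethoxyphenyl on a double-bonded chain carbon bound to a double-bonded ring carbon. The new group again carries oxygen, but as a single hydroxyl rather than two methoxy groups, and it is smaller. Among the measured compounds shown here, no measured step tells how a hydroxyl on that ring behaves; the only guide is that a bare phenyl, in compound 1, gave a higher number than compound 2, as the step of a 2.0-fold lower number from compound 1 to compound 2 (0.31 log units; beyond the scatter) shows. Compound 3 sits somewhere between these two cases, so a small shift toward a higher number, within or just beyond the scatter, is expected: a 1.4-fold higher number from compound 2 to compound 3 (0.15 log units; within the scatter). For compound 3 the estimate in this assay is 14 ug/mL, with a range from 6 ug/mL to 30 ug/mL.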

Compound 3, half-maximal inhibitory concentration: 16.4 ug/mL
The estimate for compound 3 lay 1.2-fold (0.07 log units) below the measured number, within the range that was stated.
By their numbers in this assay, from the lowest: compounds 2, 3 and 1 (each within the scatter of the next, the first and the last beyond it).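

In this assay, hydroxy in place of hydrogen on an aromatic carbon gives a 1.2-fold lower number from compound 1 to compound 3 (0.09 log units; within the scatter), so this first hydrogen-bond donor at the double-bonded chain carbon's aryl group leaves compound 3 indistinguishable from the bare phenyl of compound 1. The exchange of 3,4-dimethoxyphenyl for 4-hydroxyphenyl gives a 1.7-fold higher number from compound 2 to compound 3 (0.22 log units; within the scatter), so compound 3 also cannot be told apart from compound 2, and it stands within the scatter of both compounds, whose own gap lies beyond it; the new result therefore shows that oxygen on this aryl group does not by itself separate the compounds, and it cannot place the hydroxyl nearer to either neighbour. Nothing available here accounts for these numbers on any measured ground.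

The compounds shown leave open whether a single methoxy group on this ring would match 3,4-dimethoxyphenyl or the bare phenyl, and so whether one methoxy group or the pair goes with the step between compound 1 and compound 2. They also leave open how an amine, a carboxylic acid or a chlorine on the same ring would read in this assay.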